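The source may report more compounds than this note shows. Statements on the series, on what has been measured and on what is new or still open speak of the compounds shown alone.

Compound 1 `CCCC(=O)N1CCC(c2cc(OC)ccc2N)=N1` and compound 2 `CCCCC(=O)N1CCC(c2cc(OC)ccc2N)=N1` share one core, and compound 3 `CCC(=O)N1CCC(c2ccccc2N)=N1` and compound 4 `CCCC(=O)N1CCC(c2ccccc2N)=N1` share another; the difference between the two cores is not broken down here. In an assay on isolated protein for inhibition of Nitric oxide synthase, inducible (Homo sapiens), with a stated time of 30 min, tested at 1 mM (on this read-out higher numbers stand for more inhibition at the one concentration tested (going by the name of the read-out) and lower numbers for less inhibition), compound 1 gives 13.1%, compound 2 gives 0.18% and compound 3 gives 6.88%. The change methyl in place of hydrogen on a saturated chain carbon, three bonds along the chain from a carbonyl carbon gives a number 12.9 percentage points lower from compound 1 to compound 2 (beyond the scatter). Compound 4 carries the change (methyl in place of hydrogen on a saturated chain carbon, two bonds along the chain from a carbonyl carbon), which is the same kind of change, though its place is two bonds along the chain from a carbonyl carbon rather than three. Since compound 3 already sits low in this assay, the estimated step of a number 3.9 percentage points lower from compound 3 to compound 4 (within the scatter) is expected to be smaller than a number 12.9 percentage points lower from compound 1 to compound 2 (beyond the scatter). For compound 4 an estimated 3% is expected, between -4% and 12%.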

Compound 4, a percentage reported as inhibition, at one concentration (the size of the read-out at that concentration, not a potency): 0.35%
Beside the measured number, compound 4's estimate is 2.7 percentage points above it, within the range that was stated.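

In this assay the methyl change gives a number 6.5 percentage points lower from compound 3 to compound 4 (within the scatter), so on this core the step cannot be told from the scatter. Set beside the step on the other core, its size does not differ measurably: the same change on two cores in this assay, a number 12.9 percentage points lower (beyond the scatter) from compound 1 to compound 2 and a number 6.5 percentage points lower (within the scatter) from compound 3 to compound 4, 6.4 percentage points apart, within the scatter of two such steps

Going by these compounds alone, this rests on one pair per core, so it shows only that the two steps cannot be told apart, not that the change carries over with the same size to other cores. The separate change of hydrogen in place of methoxy gives a number 12.8 percentage points lower from compound 1 to compound 4 (beyond the scatter).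

Open, on these data alone, is how a chain longer than that of compound 2 would behave on either core. Also open, as far as these compounds go, is whether a hydroxyl or an amine in place of the methoxy would alter the step.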